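Replacing Bromo with Trifluoromethyl on Compound 1

The compounds below may be only part of what the source reports. "The series", "measured", "known", "first", "only" and "open" are said of these compounds alone.

Within the data shown here, compound 1 (`Cc1ccc(Cl)cc1-c1cc(Nc2ccc(Br)cc2)nc(N)n1`) gives 130 nM in a functional assay on DU-145 cells (Homo sapiens) for inhibition (on this read-out lower numbers stand for stronger inhibition and higher numbers for weaker inhibition), and holds the lower of the two numbers measured so far. Among the measured compounds shown here, compound 2 (`Cc1ccc(Cl)cc1-c1cc(Nc2cccc(Br)c2)nc(N)n1`) gives 400 nM in this assay and is the only close neighbour. Compound 3 (`Cc1ccc(Cl)cc1-c1cc(Nc2ccc(C(F)(F)F)cc2)nc(N)n1`) has not yet been measured. Its structure keeps everything in compound 1 except for one change, trifluoromethyl in place of bromo on an aromatic carbon, which lies para to a large group.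

For the measured compounds named here, only one measured step bears on this change (a 3.1-fold higher number from compound 1 to compound 2 (0.49 log units; beyond the scatter)). That step is modest but beyond the scatter, and it shows that a change on this part of the molecule can shift the number. It does not involve trifluoromethyl, so it offers only a rough guide to size and none to direction. A step no larger than that one is expected, with a slight rise somewhat more likely than a fall. The estimated step is small (a 1.5-fold higher number from compound 1 to compound 3 (0.19 log units; within the scatter)) and may stay within the scatter. For compound 3 the estimated value is 200 nM (range 70 nM to 600 nM).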

Compound 3, half-maximal inhibitory concentration: 230 nM
Estimate against measurement, compound 3: 1.2-fold (0.06 log units) below; measured number inside the range.
By their numbers in this assay, from the lowest: compounds 1, 3 and 2 (each within the scatter of the next, the first and the last beyond it).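

In this assay, putting trifluoromethyl in place of bromo on the aromatic carbon para to a large group gives a small step (a 1.8-fold higher number from compound 1 to compound 3 (0.25 log units; within the scatter)), so the numbers for these two compounds cannot be told apart from the ordinary spread of repeated measurements. Among these compounds, the earlier compounds showed only that relocating the bromo changes the number beyond that spread (a 3.1-fold higher number from compound 1 to compound 2 (0.49 log units; beyond the scatter)); this result adds that at the original carbon, a group of four heavy atoms can replace a single bromine with no step beyond the spread. No measurement at hand gives a reason why these two groups give such close numbers.

With only bromo and trifluoromethyl shown at this carbon, it remains open whether a quite different group there, such as an amine, a carboxylic acid or a longer chain, would also stay close to compound 1. Also open, as far as these compounds go, is whether trifluoromethyl would follow the same trend as bromo if it were placed where the bromo sits in compound 2.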